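Trimming the Aryl Group Down to a Hydroxy

This account rests on a few compounds, and the source may have more. Where it says the series, first, only, none or still open, it means among the compounds named here.

Compound 1 `CCc1ccc(OC(=O)c2cn(-c3ccccc3)nc2-c2ccncc2)cc1` is the starting point. In a functional assay on MDA-MB-231 cells (Homo sapiens) for cytotoxicity, read by MTT assay, with a stated time of 48 h (a lower number here means a stronger inhibitor, a higher number a weaker inhibitor), compound 1 gives > 100000 nM, which is a limit of the assay rather than a number. Compound 2 `O=C(Oc1ccc(-c2ccccc2)cc1)c1cn(-c2ccccc2)nc1-c1ccncc1` carries phenyl in place of ethyl on an aromatic carbon. In this assay compound 2 gives > 100000 nM, again a limit and not a number. The step that the two limits leave unreadable from compound 1 to compound 2 therefore cannot be read, because of the limit of > 100000 nM in this assay, at which 2 of the 2 values shown sit. Compound 1 thus stands only at a limit, with no number placed beneath it.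

Compound 3 `O=C(O)c1cn(-c2ccccc2)nc1-c1ccncc1` differs from compound 1 by hydrogen in place of 4-ethylphenyl on an oxygen next to a carbonyl group, so the 4-ethylphenoxy becomes a hydroxy on the carbonyl. Within the data shown here, the single measured step, a step that the two limits leave unreadable from compound 1 to compound 2, concerns a different place and is itself unreadable, so it gives no guide to the size or direction of the present change in this assay. With both measured compounds sitting at the limit, the expectation is that compound 3 likewise shows no measurable inhibition. For compound 3 the estimated value is 200000 nM, expected to lie between 50000 nM and 1000000 nM. The step this estimate implies, a step that the limit leaves unreadable from compound 1 to compound 3, is expected to stay within the scatter.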

Compound 3, half-maximal inhibitory concentration: > 100000 nM
Compound 3: only a limit was reported (the forecaster's own chance of this, stated with the estimate: 85%); the middle value lies beyond the limit too.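

Compound 3 gives > 100000 nM in this assay, again a limit and not a number. The steps among compound 1, compound 2 and compound 3 therefore cannot be read: the limit of > 100000 nM in this assay, at which 3 of the 3 values shown sit. Whether any close relative of these compounds reaches a measurable value in this assay, and how much a single change would then matter, stays open.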